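Swapping Methylsulfamoyl for Carbamoyl on the Pendant Phenyl

The source may hold more compounds than are shown below. What is called first, only, known or untested is meant among the compounds shown, and "the series" means these compounds.

Compound 3 `CCCS(=O)(=O)Nc1ccc(F)c(C(=O)c2n[nH]c3ncc(-c4ccc(S(=O)(=O)NC)cc4)cc23)c1F` is the point of departure. In an assay for binding affinity to dual specificity mitogen-activated protein kinase kinase 4 (Homo sapiens), read by KINOMEscan, tested at 100 nM (on this read-out higher numbers stand for a weaker effect at the one concentration tested and lower numbers for a stronger effect), compound 3 gives 1.2%, the lowest of the three numbers at hand. Compound 2 `CCCS(=O)(=O)Nc1ccc(F)c(C(=O)c2n[nH]c3ncc(-c4ccc(OC)cc4Cl)cc23)c1F` gives 5.3%, and the step of a number 4.1 percentage points lower from compound 2 to compound 3 (within the scatter) stays within the scatter, so the two cannot be ordered. Compound 1 `CCCS(=O)(=O)Nc1ccc(F)c(C(=O)c2n[nH]c3ncc(-c4ccc(C(C)C)cc4)cc23)c1F` gives 17%, and the step of a number 15.8 percentage points lower from compound 1 to compound 3 (beyond the scatter) lies beyond the scatter, as does the step of a number 11.7 percentage points lower from compound 1 to compound 2 (beyond the scatter).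

Compound 4 `CCCS(=O)(=O)Nc1ccc(F)c(C(=O)c2n[nH]c3ncc(-c4ccc(C(N)=O)cc4)cc23)c1F` differs from compound 3 in a single place: carbamoyl in place of methylsulfamoyl on an aromatic carbon. Among the compounds with values here, two measured steps touch the same aromatic carbon. The step of a number 15.8 percentage points lower from compound 1 to compound 3 (beyond the scatter) was modest, while the step of a number 4.1 percentage points lower from compound 2 to compound 3 (within the scatter) was within the scatter; in other words, once isopropyl is gone, the two groups tried in its place gave numbers that cannot be told apart. Carbamoyl, like the methylsulfamoyl it replaces, brings one hydrogen-bond donor and at least one acceptor, so the closest analogy is the step from compound 2 to compound 3 rather than the one from compound 1. The expected step is therefore a number 2.8 percentage points higher from compound 3 to compound 4 (within the scatter), with no change beyond the scatter. Compound 4 is estimated to give 4%, with a range from 1% to 12%.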

Compound 4, a percentage reported as activity, at one concentration (the size of the read-out at that concentration, not a potency): 0.15%
Compound 4: the middle estimate sits 3.9 percentage points above what was measured, outside the stated range (below it).
By their numbers in this assay, from the lowest: compounds 4, 3 and 2 (each within the scatter of the next); then compound 1.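

Carbamoyl in place of methylsulfamoyl, with fewer heavy atoms at this aromatic carbon para to a large group, leaves the number in this assay where it was (the step is a number 1.1 percentage points lower from compound 3 to compound 4 (within the scatter)), so the sulfonyl-based group is not needed to keep the read-out low and the shorter carbamoyl serves as well. Set against the other two groups, carbamoyl again cannot be told apart from the 2-chloro-4-methoxyphenyl compound (the step is a number 5.2 percentage points lower from compound 2 to compound 4 (within the scatter)), but it stands clearly apart from isopropyl (the step is a number 16.9 percentage points lower from compound 1 to compound 4 (beyond the scatter)), which makes compound 1 the only one of the four compounds that separates from the rest. Nothing at hand bears on the reason for this result.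

Open, from the compounds shown here alone, is whether a carboxylic acid, a nitrile or a primary amine on the same aromatic carbon would stay with compound 4 or move towards compound 1. Also open, going by these compounds, is whether compound 2, compound 3 and compound 4, which this single concentration cannot order, would separate into stronger and weaker effects at other concentrations.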